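The compounds below may be only part of what the source reports. "The series", "measured", "known", "first", "only" and "open" are said of these compounds alone.

Within the data shown here, in a functional assay on PC-3 cells (Homo sapiens) for inhibition, read by sulforhodamine B assay, with a stated time of 48 h (on this read-out higher numbers stand for weaker inhibition and lower numbers for stronger inhibition), compound 3 (`O=C(Nc1ccc2c(c1)CCN2c1ccc(C(=O)NO)cc1)Nc1ccc(Cl)c(C(F)(F)F)c1`) gives 3800 nM, the only true number so far. Compound 1 (`O=C(Nc1ccc(Nc2ncc(C(=O)NO)cn2)cc1)Nc1ccc(Cl)c(C(F)(F)F)c1`) reads > 10000 nM, which is a limit of the assay. Compound 2 (`O=C(CCCCC(=O)Nc1ccc(NC(=O)Nc2ccc(Cl)c(C(F)(F)F)c2)cc1)NO`) reads > 10000 nM, also a limit. Among the measured compounds shown here, these two compounds stand at the limit of > 10000 nM in this assay, at which 2 of the 3 values shown sit, so the single measured step, a step that the two limits leave unreadable from compound 1 to compound 2, has no size to carry over. Compound 4 (`O=C(Nc1ccc2c(c1)CCN2Cc1ccc(C(=O)NO)cc1)Nc1ccc(Cl)c(C(F)(F)F)c1`) changes compound 3 at one place: 4-(hydroxycarbamoyl)benzyl in place of 4-(hydroxycarbamoyl)phenyl on a nitrogen on an aromatic ring in a ring, with 4-(hydroxycarbamoyl)benzyl in place of 4-(hydroxycarbamoyl)phenyl. For the measured compounds named here, no measured step covers this change, so the only anchor is compound 3 at 3800 nM, and no shift beyond the usual scatter is expected in this assay. The expected step is a 1.3-fold lower number from compound 3 to compound 4 (0.10 log units; within the scatter). For compound 4 the estimated value is 3000 nM, with an expected range from 800 nM to 10000 nM.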

Compound 4, half-maximal inhibitory concentration: 3400 nM
Estimate against measurement, compound 4: 1.1-fold (0.05 log units) below; the measured number falls inside the stated range.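

Among these compounds, replacing 4-(hydroxycarbamoyl)phenyl with 4-(hydroxycarbamoyl)benzyl, on a nitrogen on an aromatic ring in a ring, gives the first readable step in this assay: a 1.1-fold lower number from compound 3 to compound 4 (0.05 log units; within the scatter). So one more carbon at this position leaves the number within the scatter. Compound 1 and compound 2 both stay at a limit, and the step joining them cannot be read: the limit of > 10000 nM in this assay, at which 2 of the 4 values shown sit.

The compounds shown leave open whether a longer chain on this nitrogen would move the number beyond the scatter. They also leave open what a carboxylic acid in place of the hydroxycarbamoyl group would do.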